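Methylation of one catechol hydroxyl in the hydrazone series

A few compounds are considered here, and "the series" means these few. Any claim that something is new, unique, unknown or untested is made for them only; others in the source may bear on it.

Within the data shown here, compound 2 `O=C(CSc1nnc(-c2ccncc2)o1)N/N=C/c1ccc(O)c(O)c1` gives the lowest number of the two measured so far in a functional assay on MCF7 cells (Homo sapiens) for cytotoxicity, read by MTT assay, with a stated time of 48 h (a lower number here means a stronger inhibitor, a higher number a weaker inhibitor), 910 nM, against compound 1 `O=C(CSc1nnc(-c2ccncc2)o1)N/N=C/c1cccc(F)c1` at 24900 nM. Among the measured compounds shown here, the one step on record, a 27-fold lower number from compound 1 to compound 2 (1.44 log units; beyond the scatter), shows the 3,4-dihydroxyphenyl unit carries most of the potency. Compound 3 `COc1cc(/C=N/NC(=O)CSc2nnc(-c3ccncc3)o2)ccc1O` differs by methyl in place of hydrogen on an oxygen on an aromatic ring, hydroxy to methoxy, 3,4-dihydroxyphenyl to 4-hydroxy-3-methoxyphenyl. For the measured compounds named here, no measured step covers this change; it removes one of the two hydroxy groups that made the big step, so a loss beyond the scatter is expected, smaller than that step. Compound 3 is estimated at 3000 nM, range 900 nM to 12000 nM, a step of a 3.3-fold higher number from compound 2 to compound 3 (0.52 log units; beyond the scatter).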

Compound 3, half-maximal inhibitory concentration: 3780 nM
Beside the measured number, compound 3's estimate is 1.3-fold (0.10 log units) below it; measured number inside the range.
By their numbers in this assay, from the lowest: compound 2; then compound 3; then compound 1.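

Read in this assay the methyl in place of hydrogen on an oxygen on an aromatic ring costs potency (a 4.2-fold higher number from compound 2 to compound 3 (0.62 log units; beyond the scatter)), so the second free hydroxy counts at this position. Even so, 4-hydroxy-3-methoxyphenyl keeps part of the gain over 3-fluorophenyl (a 6.6-fold lower number from compound 1 to compound 3 (0.82 log units; beyond the scatter)), so both free hydroxy groups are not required for that gain. No measurement given here bears on the reason for either step.

Open, going by these compounds, is whether the remaining hydroxy can also be replaced. An ethyl on the same oxygen, or an amine in place of the hydroxy, would test how much this position tolerates.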